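Methyl on a Sulfonamide Nitrogen: What to Expect

The compounds below may be only part of what the source reports. "The series", "measured", "known", "first", "only" and "open" are said of these compounds alone.

Three compounds have been measured in an assay on isolated protein for activation of Nicotinamide phosphoribosyltransferase (Homo sapiens); a higher number here means that more compound is needed for the effect, a lower number that less compound is needed:

compound 1, `O=C(NCc1ccncc1)Nc1ccc(S(=O)(=O)Nc2ccccc2)cc1`: 410 nM
compound 2, `CN(Cc1ccccc1)S(=O)(=O)c1ccc(NC(=O)NCc2ccncc2)cc1`: 23 nM
compound 3, `NS(=O)(=O)c1ccc(NC(=O)NCc2ccncc2)cc1`: 14300 nM

Within this set compound 3 gives the highest number in this assay; its steps to the other two, a 35-fold higher number from compound 1 to compound 3 (1.54 log units; beyond the scatter) and a 620-fold higher number from compound 2 to compound 3 (2.79 log units; beyond the scatter), both lie beyond the scatter. Compound 4, `CNS(=O)(=O)c1ccc(NC(=O)NCc2ccncc2)cc1`, differs from compound 3 by methyl in place of hydrogen on a sulfonamide nitrogen. The two steps that bear on this change are those just named: each time a group sits on that sulfonamide nitrogen instead of hydrogen, the number falls, by a large margin. A methyl group is far smaller than phenyl or benzyl(methyl), so only a modest fall is expected for compound 4, a 2.9-fold lower number from compound 3 to compound 4 (0.46 log units; beyond the scatter). The estimate for compound 4 is 5000 nM, with a range from 1500 nM to 15000 nM.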

Compound 4, half-maximal effective concentration: 3230 nM
The estimate for compound 4 lay 1.5-fold (0.19 log units) above the measured number; the measured number falls inside the stated range.
By their numbers in this assay, from the lowest: compound 2; then compound 1; then compound 4; then compound 3.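

Even the single carbon of methyl counts on this sulfonamide nitrogen, as a 4.4-fold lower number from compound 3 to compound 4 (0.65 log units; beyond the scatter) shows. Methyl alone does not match the larger groups, though: the steps are a 140-fold higher number from compound 2 to compound 4 (2.15 log units; beyond the scatter) and a 7.9-fold higher number from compound 1 to compound 4 (0.90 log units; beyond the scatter) and both leave compound 4 with the higher number. No measurement shown here explains these differences. Open, from the compounds shown here alone, is whether ethyl or a longer chain on that nitrogen would lower the number further, and how benzyl alone, without the accompanying methyl, would compare.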